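Methoxy Addition on the Benzoyl Ring of Compound 3

This account rests on a few compounds, and the source may have more. Where it says the series, first, only, none or still open, it means among the compounds named here.

Compound 1 `COc1ccc(C(=O)n2c(-c3cn(C)c4ccccc34)nc3ccccc32)cc1OC` gives 3100 nM in a functional assay on A549 cells (Homo sapiens) for inhibition, read by MTT assay, with a stated time of 24 h; on this read-out lower numbers stand for stronger inhibition of growth and higher numbers for weaker inhibition of growth. Compound 2 `COc1cc(C(=O)n2c(-c3cn(C)c4ccccc34)nc3ccccc32)cc(OC)c1OC` carries methoxy in place of hydrogen on an aromatic carbon and gives 2600 nM in this assay; the step is a 1.2-fold lower number from compound 1 to compound 2 (0.08 log units; within the scatter). Compound 3 `COc1ccc2c(c1)c(-c1nc3ccccc3n1C(=O)c1ccccc1)cn2C` has another core, and the difference between the two cores is not broken down here. In this assay compound 3 gives 16700 nM, the highest number of the three measured. Compound 4 `COc1ccc2c(c1)c(-c1nc3ccccc3n1C(=O)c1ccccc1OC)cn2C` is not yet measured; it carries methoxy in place of hydrogen on an aromatic carbon. Within the data shown here, this is the same kind of change as the one leading to compound 2, but the place differs: here the methoxy enters ortho to a large group, whereas in compound 2 it enters ortho to a methoxy group, meta to a large group and meta to a methoxy group. For compound 4 the expected step in this assay is a 1.3-fold lower number from compound 3 to compound 4 (0.11 log units; within the scatter), because the earlier step of a 1.2-fold lower number from compound 1 to compound 2 (0.08 log units; within the scatter) was small; the changed surroundings widen the uncertainty. Compound 4 is estimated at 13000 nM in this assay, between 4500 nM and 38000 nM.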

Compound 4, concentration for 50% growth inhibition: 11900 nM
Compound 4: middle estimate off by 1.1-fold (0.04 log units), on the high side; the measured number falls inside the stated range.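

In this assay, the methoxy step on the core of compound 3 reads a 1.4-fold lower number from compound 3 to compound 4 (0.15 log units; within the scatter), and it matches the step on the other core: the same change on two cores in this assay, a 1.2-fold lower number (0.08 log units; within the scatter) from compound 1 to compound 2 and a 1.4-fold lower number (0.15 log units; within the scatter) from compound 3 to compound 4, 1.2-fold (0.07 log units) apart, within the scatter of two such steps On these two pairs, the change carries over between cores as a step too small to read, on either core. Among these compounds, this does not show a real effect of methoxy that transfers, and with only two pairs, with the methoxy entering at different places, it sets no rule for the series.

The compounds shown leave open whether an amine, a carboxylic acid or a longer alkoxy chain in place of this methoxy would give a step beyond the scatter. Going by these compounds, whether such a step would then carry between the two cores also remains open.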